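Dodecyl amide with a dienoyl cap in place of benzofuran

A few compounds are considered here, and "the series" means these few. Any claim that something is new, unique, unknown or untested is made for them only; others in the source may bear on it.

The series rests on a threonine-derived core bearing an alkyl amide and an acyl group on the amine. Compound 1 `CCCCCCCCNC(=O)[C@@H](NC(=O)c1ccco1)[C@@H](C)O` gives 192000 nM in a functional assay on HepG2 cells (Homo sapiens) for cytotoxicity, read by MTT assay, with a stated time of 48 h; a lower number here means a stronger inhibitor, a higher number a weaker inhibitor. Compound 2 `CCCCCCCCNC(=O)[C@@H](NC(=O)c1cc2ccccc2o1)[C@@H](C)O` gives 81300 nM, and compound 3 `CCCCCCCCCCCCNC(=O)[C@@H](NC(=O)c1cc2ccccc2o1)[C@@H](C)O` gives 22900 nM, the lowest of the three numbers. The two measured steps were a 2.4-fold lower number from compound 1 to compound 2 (0.37 log units; beyond the scatter) and a 3.6-fold lower number from compound 2 to compound 3 (0.55 log units; beyond the scatter). Compound 4 `C/C=C/C=C/C(=O)N[C@H](C(=O)NCCCCCCCCCCCC)[C@@H](C)O` differs from compound 3 in one place: penta-1,3-dien-1-yl in place of 1-benzofuran-2-yl on a carbonyl carbon. Only the first step bears on this change, since it also altered the group on that carbonyl carbon, and it showed that the larger 1-benzofuran-2-yl gave a lower number than furan-2-yl. Going to an open penta-1,3-dien-1-yl with no ring is expected to move the number back up, by a modest amount, so the step of a 2.2-fold higher number from compound 3 to compound 4 (0.34 log units; beyond the scatter) is the expected outcome. Compound 4 is therefore estimated at 50000 nM, with a range from 15000 nM to 160000 nM.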

Compound 4, half-maximal inhibitory concentration: > 400000 nM
Compound 4 ended at the assay's limit (the forecaster's own chance of this, stated with the estimate: 5%); middle value at least 8.0-fold (0.90 log units) away from the limit.
By their numbers in this assay, from the lowest: compound 3; then compound 2; then compound 1. At a limit, above all of these: compound 4.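

The group on this carbonyl carbon proves to matter far more than the ring-for-ring swap suggested: that swap gave only a 2.4-fold lower number from compound 1 to compound 2 (0.37 log units; beyond the scatter), whereas penta-1,3-dien-1-yl in place of 1-benzofuran-2-yl gives an at least 17-fold higher number from compound 3 to compound 4 (1.24 log units; beyond the scatter). This change also outweighs the chain step, a 3.6-fold lower number from compound 2 to compound 3 (0.55 log units; beyond the scatter), and the dodecyl amide shared by both compounds does not keep the number low once the rings are gone. The value for compound 4 is a limit of the assay and not a number: the limit of > 400000 nM in this assay, at which 1 of the 4 values shown sits.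

The open question is whether the rings or the double bonds decide this, and a phenyl or a saturated pentyl group on the same carbonyl carbon would separate the two. On these data alone, it also remains open whether a longer chain, such as hexadecyl, would bring the number of the dienyl amide back within range.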